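The source may report more compounds than this note shows. Statements on the series, on what has been measured and on what is new or still open speak of the compounds shown alone.

Working notes on the series. In a functional assay on NCI-H322M cells (Homo sapiens) for inhibition, read by sulforhodamine B assay, with a stated time of 48 h (on this read-out lower numbers stand for stronger inhibition of growth and higher numbers for weaker inhibition of growth), compound 1 `Nc1cc(N)c2nc(-c3ccccc3)c(Oc3ccc(Cl)c(Cl)c3)nc2c1` gives 58900 nM, the higher of the two plain numbers in hand. Compound 3 `COc1ccc(CNc2nc3cc(N)cc(N)c3nc2-c2ccccc2)cc1` gives 52500 nM in this assay, and that value and the value of compound 1 sit within the usual scatter of each other, so no order between them is claimed. Compound 2 `CCOC(=O)[C@H](CCC(=O)O)NC(=O)c1ccc(CNc2nc3cc(N)cc(N)c3nc2-c2ccccc2)cc1` returns only a limit in this assay, < 100000 nM, which is the limit of < 100000 nM in this assay, at which 1 of the 3 values shown sits, and not a number.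

Compound 4 `Nc1cc(N)c2nc(-c3ccccc3)c(Sc3ccc(F)cc3)nc2c1` is not yet measured. It carries (4-fluorophenyl)sulfanyl in place of 3,4-dichlorophenoxy on an aromatic carbon, with the rest of the core of compound 1 kept. Within the data shown here, no measured pair with a change of this kind is available, so no direction can be read from the numbers; the expected step from compound 1 to compound 4 is a 1.2-fold lower number from compound 1 to compound 4 (0.07 log units; within the scatter), none beyond the scatter. Compound 4 is therefore estimated at 50000 nM in this assay, with a range from 15000 nM to 100000 nM.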

Compound 4, concentration for total growth inhibition: 38000 nM
Beside the measured number, compound 4's estimate is 1.3-fold (0.12 log units) above it; measured number inside the range.
By their numbers in this assay, from the lowest: compounds 4, 3 and 1 (each within the scatter of the next).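

In this assay, (4-fluorophenyl)sulfanyl in place of 3,4-dichlorophenoxy on this aromatic carbon gives a 1.6-fold lower number from compound 1 to compound 4 (0.19 log units; within the scatter). This first one-place comparison in the series shows that this exchange at this position leaves the number within the scatter, with the linking atom and the ring halogens changing together. Nothing measured here gives a reason for the step.

The shares of the linking atom and the ring halogens in this step remain unseparated, as a 4-fluorophenoxy group would be needed to compare them. As far as these compounds go, whether a piperazine on this carbon would move the number beyond the scatter also remains open.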